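The compounds below may be only part of what the source reports. "The series", "measured", "known", "first", "only" and "open" are said of these compounds alone.

In a functional assay on SW-620 cells (Homo sapiens) for cytotoxicity, read by MTT assay, with stated times of 4 h and 72 h, tested at 2 uM (a lower number here means a stronger inhibitor, a higher number a weaker inhibitor), compound 1 `COc1ccc(/C=C/C(=O)c2ccc(Nc3cc(C)nc4nc(SCc5nc6ccccc6[nH]5)nn34)cc2)cc1` gives 170 nM and compound 2 `Cc1cc(Nc2ccc(C(=O)/C=C/c3ccc(OC(F)(F)F)cc3)cc2)n2nc(SCc3nc4ccccc4[nH]3)nc2n1` gives 220 nM so the two stand level within the scatter. Compound 3 `Cc1cc(Nc2ccc(C(=O)/C=C/c3ccccc3)cc2)n2nc(SCc3nc4ccccc4[nH]3)nc2n1` follows from compound 2 by one change: hydrogen in place of trifluoromethoxy on an aromatic carbon that is, hydrogen in place of trifluoromethoxy on an aromatic carbon. Among the measured compounds shown here, the one measured step that bears on this change is a 1.3-fold higher number from compound 1 to compound 2 (0.11 log units; within the scatter) and it lies within the scatter, with trifluoromethyl in place of methyl on an oxygen on an aromatic ring. For the measured compounds named here, that step keeps the oxygen, so no measured compound shows the whole group gone. No step beyond the scatter is therefore expected in this assay and no direction is favoured. a 1.1-fold higher number from compound 2 to compound 3 (0.06 log units; within the scatter) is the estimated step. For compound 3 the expected range runs from 100 nM to 620 nM around an estimated 250 nM as the middle value.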

Compound 3, half-maximal inhibitory concentration: 130 nM
Beside the measured number, compound 3's estimate is 1.9-fold (0.28 log units) above it, and the stated range covers the measured number.
By their numbers in this assay, from the lowest: compounds 3, 1 and 2 (each within the scatter of the next).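

In this assay, the whole group on the aromatic carbon para to a large group can now be read, not only the change on its oxygen (hydrogen for trifluoromethoxy: a 1.7-fold lower number from compound 2 to compound 3 (0.23 log units; within the scatter); hydrogen for methoxy: a 1.3-fold lower number from compound 1 to compound 3 (0.12 log units; within the scatter)). Both steps lie within the scatter, so among the three compounds shown, the 4-(trifluoromethoxy)phenyl, its methoxy counterpart and the plain phenyl stand level, and this position shows no requirement for either oxygen-linked group. No measurement on hand gives a reason for this flat result.

Still open, as far as these compounds go, is whether a different group at this carbon, such as an amine or a carboxylic acid, would produce a step beyond the scatter. The compounds shown also leave open whether the same flatness holds when the shared core changes.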